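A few compounds are considered here, and "the series" means these few. Any claim that something is new, unique, unknown or untested is made for them only; others in the source may bear on it.

Measured compounds:
compound 1, `Cc1cccc(-c2noc(C3CN(C(=O)C4CCC(C(F)(F)F)CC4)C3)n2)c1` — > 10000 nM
compound 2, `O=C(C1CCC(C(F)(F)F)CC1)N1CC(c2nc(-c3cccc(Cl)c3)no2)C1` — > 10000 nM
compound 3, `O=S(=O)(c1ccc(Cl)cc1)N1CC(c2nc(-c3cccc(Cl)c3)no2)C1` — 170 nM

In an assay on HEK293 cells for negative allosteric modulation of metabotropic glutamate receptor 5 (Homo sapiens), read by FLIPR (a lower number here means a stronger inhibitor, a higher number a weaker inhibitor), compound 1 gives > 10000 nM, which is a limit of the assay and not a number. Compound 2 gives > 10000 nM, again a limit. Within the data shown here, compound 3 is the only member of the set with a number in this assay, 170 nM. The difference between the core of compound 2 and the core of compound 3 is not broken down here.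

The change from compound 2 to compound 1 is methyl in place of chloro on an aromatic carbon. The step it made in this assay is a step that the two limits leave unreadable from compound 2 to compound 1; with the limit of > 10000 nM in this assay, at which 2 of the 3 values shown sit, on both sides, the size of that step cannot be read.

Compound 4, `Cc1cccc(-c2noc(C3CN(S(=O)(=O)c4ccc(Cl)cc4)C3)n2)c1`, is not yet measured. Among the measured compounds shown here, it differs from compound 3 by methyl in place of chloro on an aromatic carbon, the same change as the one from compound 2 to compound 1, at the same place. Since the earlier example of this change gives no readable size, the expectation for compound 4 rests only on the value of compound 3, 170 nM, as its starting point. For the measured compounds named here, the step the estimate means, a 2.1-fold higher number from compound 3 to compound 4 (0.31 log units; beyond the scatter), is expected to stay modest, as nothing among the measured compounds indicates a large shift for this change. Compound 4 is therefore estimated at 350 nM in this assay, with a range from 100 nM to 1500 nM.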

Compound 4, half-maximal inhibitory concentration: 1100 nM
The estimate for compound 4 lay 3.1-fold (0.50 log units) below the measured number; low and high end bracket the measured number.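

In this assay, methyl in place of chloro on the core of compound 3, read as 3-chlorophenyl to 3-methylphenyl, gives one readable step (a 6.5-fold higher number from compound 3 to compound 4 (0.81 log units; beyond the scatter)), and on this core it weakens inhibition. The same change on the core of compound 2 cannot be read, as compound 2 and compound 1 both stand at a limit of the assay and not at a number. This pair therefore shows the size of the change on one core only and does not show whether that size, or even its direction, carries over to the other core, and the obstacle to the comparison lies in the values themselves: the limit of > 10000 nM in this assay, at which 2 of the 4 values shown sit.

On these data alone, it remains open how other groups at the same place on the aromatic ring, such as fluoro, methoxy or nitrile, would stand relative to compound 3 and compound 4 on this core. Also open, as far as these compounds go, is whether an amine or a carboxylic acid in place of the trifluoromethyl on the core of compound 2 would bring that core into a readable range, which would allow a second reading of the chloro to methyl change.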